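Varying the amide substituent in a phenylethynyl-pyridine series

The source may report more compounds than this note shows. Statements on the series, on what has been measured and on what is new or still open speak of the compounds shown alone.

Three compounds share one core and differ only in what sits on the amide-type nitrogen. Compound 1 `NC(=O)c1ccc(C#Cc2ccccc2)nc1` carries a hydrogen there and in a functional assay on BHK cells for positive allosteric modulation of metabotropic glutamate receptor 5 (Homo sapiens), read by FLIPR and calcium flux (a lower number here means that less compound is needed, a higher number that more compound is needed for the effect), compound 1 gives 6600 nM. Compound 2 `O=C(NC1CCCC1)c1ccc(C#Cc2ccccc2)nc1` carries a cyclopentyl group, and in this assay compound 2 gives 30 nM. Compound 3 `O=C(NC1CCCCC1)c1ccc(C#Cc2ccccc2)nc1` carries a cyclohexyl group; in this assay compound 3 gives 240 nM, which places it second highest of the three numbers: the step of an 8.0-fold higher number from compound 2 to compound 3 (0.90 log units; beyond the scatter) separates it from its nearest neighbour, and the step of a 28-fold lower number from compound 1 to compound 3 (1.44 log units; beyond the scatter) from the furthest.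

The next compound, compound 4 `O=C(NCc1ccco1)c1ccc(C#Cc2ccccc2)nc1`, changes this position once more: (furan-2-yl)methyl in place of cyclohexyl on an amide-type nitrogen. Among the measured compounds shown here, two measured steps bear on it. The steps of a 220-fold lower number from compound 1 to compound 2 (2.34 log units; beyond the scatter) and a 28-fold lower number from compound 1 to compound 3 (1.44 log units; beyond the scatter) show that any of the tested groups on the amide-type nitrogen lowers the number strongly, while the step of an 8.0-fold higher number from compound 2 to compound 3 (0.90 log units; beyond the scatter) shows that the choice of group still shifts the number by a modest amount. For the measured compounds named here, no measured compound carries a group resembling (furan-2-yl)methyl, so the direction of this step is uncertain; a modest change in either direction is expected. Compound 4 is therefore estimated at 150 nM, between 30 nM and 800 nM, a step of a 1.6-fold lower number from compound 3 to compound 4 (0.20 log units; within the scatter).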

Compound 4, half-maximal effective concentration: 180 nM
The estimate for compound 4 lay 1.2-fold (0.08 log units) below the measured number; low and high end bracket the measured number.
By their numbers in this assay, from the lowest: compound 2; then compounds 4 and 3 (each within the scatter of the next); then compound 1.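

In this assay, (furan-2-yl)methyl in place of cyclohexyl on the amide-type nitrogen gives a 1.3-fold lower number from compound 3 to compound 4 (0.12 log units; within the scatter), so at this position the two groups cannot be told apart, although one is a six-membered non-aromatic ring of carbon only and the other a five-membered aromatic ring with a hydrogen-bond acceptor. The strong drop from the amide hydrogen now also holds for a group with a hetero atom, at a 37-fold lower number from compound 1 to compound 4 (1.56 log units; beyond the scatter), while cyclopentyl stays clearly ahead of this new group as well, at a 6.0-fold higher number from compound 2 to compound 4 (0.78 log units; beyond the scatter). No supporting information is available that would explain these results.

The compounds shown leave open how the ring oxygen and the methyl link of (furan-2-yl)methyl each count, which a benzyl or a cyclopentylmethyl group on the amide-type nitrogen would help to separate. Also open, from the compounds shown here alone, is whether the low number of compound 2, at 30 nM, belongs to cyclopentyl alone or extends to a cyclobutyl group or to an open chain such as pentyl.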